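Replacing the methylamino group of compound 3 with hydroxy

A few compounds are considered here, and "the series" means these few. Any claim that something is new, unique, unknown or untested is made for them only; others in the source may bear on it.

In a functional assay on A549 cells (Homo sapiens) for inhibition, read by sulforhodamine B assay, with a stated time of 72 h (on this read-out higher numbers stand for weaker inhibition of growth and lower numbers for stronger inhibition of growth), compound 1 `CCOC(=O)/C=C/c1ccncc1-c1ccc2[nH]ccc2c1` gives 7440 nM. Compound 3 `CNC(=O)/C=C/c1ccncc1-c1ccc2[nH]ccc2c1` reads > 10000 nM, which is a limit of the assay. The series thus meets (the limit of > 10000 nM in this assay, at which 2 of the 3 values shown sit). Going by the values given here, the one measured step at this carbonyl carbon is an at least 1.3-fold higher number from compound 1 to compound 3 (0.12 log units; that floor lies within the scatter). Compound 4 `O=C(O)/C=C/c1ccncc1-c1ccc2[nH]ccc2c1` follows through (hydroxy in place of methylamino on a carbonyl carbon), with hydroxy in place of methylamino on a carbonyl carbon. Compound 2 `Cn1ccc2cc(-c3cnccc3/C=C/C(=O)O)ccc21`, which also carries a carboxy group, reads > 10000 nM, again a limit, and this points towards weak inhibition of growth by compound 4. No change beyond the scatter is expected, and the estimated step is a step that the limit leaves unreadable from compound 3 to compound 4. Compound 4 is estimated at 13000 nM, with an expected range of 6000 nM to 30000 nM.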

Compound 4, concentration for 50% growth inhibition: > 10000 nM
Compound 4 ended at the assay's limit; the forecaster's own chance of this, stated with the estimate: 75%; the middle value does not contradict the limit.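

At this carbonyl carbon, hydroxy now joins methylamino as a replacement for ethoxy, and in this assay compound 4 also stands at a limit of the assay. Replacing the ethyl on that oxygen gives an at least 1.3-fold higher number from compound 1 to compound 4 (0.12 log units; that floor lies within the scatter). The steps to compound 4 from compound 3 and from compound 2 cannot be read, and the series now gathers at one ceiling: the limit of > 10000 nM in this assay, at which 3 of the 4 values shown sit.

From the compounds shown here alone, whether any group on this carbonyl carbon can give a reading clearly stronger than the ethoxy compound stays open. An isopropoxy group, a benzyloxy group or a dimethylamino group in this place would bear on that.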